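From 1H-imidazol-1-yl to dimethylamino on the amide chain

The source may report more compounds than this note shows. Statements on the series, on what has been measured and on what is new or still open speak of the compounds shown alone.

Among the compounds with values here, in an ADME assay on RD cells (Homo sapiens) for cytotoxicity, read by neutral red uptake, with a stated time of 3 days (on this read-out higher numbers stand for lower toxicity in this test and lower numbers for higher toxicity in this test), compound 2 (`O=C(NCCCn1ccnc1)c1cc(-c2cccs2)nc2ccccc12`) gives 55700 nM as the lower of the two numbers so far, and compound 1 (`CC(C)Oc1cc(C(=O)NCCCN(C)C)c2ccccc2n1`) gives the higher number (122000 nM). Compound 3 (`CN(C)CCCNC(=O)c1cc(-c2cccs2)nc2ccccc12`) keeps the core of compound 2 and carries dimethylamino in place of 1H-imidazol-1-yl on a saturated chain carbon, three bonds along the chain from an amide-type nitrogen. Compound 1 has the same dimethylamino chain on a different core and is only a loose guide. In this assay the expected step of a 1.1-fold lower number from compound 2 to compound 3 (0.05 log units; within the scatter) stays within the scatter. For compound 3 the expected value is 50000 nM (range 18000 nM to 130000 nM).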

Compound 3, half-maximal cytotoxic concentration: 40500 nM
The estimate for compound 3 lay 1.2-fold (0.09 log units) above the measured number; the range from low to high includes it.
By their numbers in this assay, from the lowest: compounds 3 and 2 (each within the scatter of the next); then compound 1.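

In this assay, dimethylamino in place of 1H-imidazol-1-yl gives a 1.4-fold lower number from compound 2 to compound 3 (0.14 log units; within the scatter) on the shared core, so these two chain ends cannot be told apart at this position. Within the data shown here, with the dimethylamino chain held, thiophen-2-yl in place of isopropoxy on an aromatic carbon gives a 3.0-fold lower number from compound 1 to compound 3 (0.48 log units; beyond the scatter), the only step so far beyond the scatter. No available measurement accounts for either step.

Still open, from the compounds shown here alone, is whether a morpholine at the chain end or a longer chain would also stay within the scatter of compound 3. Also open, going by these compounds, is whether a phenyl ring in place of thiophen-2-yl would give a step of similar size.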